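Swapping the urea's aryl group on a pyrazole cell-growth series

The source may report more compounds than this note shows. Statements on the series, on what has been measured and on what is new or still open speak of the compounds shown alone.

Three compounds were tested in a functional assay on HOP-62 cells (Homo sapiens) for inhibition, read by sulforhodamine B assay, with a stated time of 48 h, tested at 1 uM; on this read-out lower numbers stand for a stronger effect and higher numbers for a weaker effect at the one concentration tested. Compound 1 `COc1cc(Cl)cc(-c2nn(-c3cccc(NC(=O)Nc4cccc(C(F)(F)F)c4)c3)cc2-c2ccncc2)c1` gives 85%, the lowest of the three numbers. Among the measured compounds shown here, compound 2 `COc1cc(Cl)cc(-c2nn(-c3cccc(NC(=O)c4cccc(C(F)(F)F)c4)c3)cc2-c2ccncc2)c1` gives 101%, and the one measured single-point change, a number 16 percentage points higher from compound 1 to compound 2 (beyond the scatter), is a modest move to a weaker effect. Compound 3 `O=C(Nc1cccc(-n2cc(-c3ccncc3)c(-c3cc(O)cc(Cl)c3)n2)c1)Nc1ccc(Cl)c(Cl)c1` gives 97%, also a higher number than compound 1.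

Compound 4 `COc1cc(Cl)cc(-c2nn(-c3cccc(NC(=O)Nc4ccc(Cl)c(Cl)c4)c3)cc2-c2ccncc2)c1` differs from compound 1 by 3,4-dichlorophenyl in place of 3-(trifluoromethyl)phenyl on an amide-type nitrogen. For the measured compounds named here, no measured step isolates this change; compound 3 carries the same 3,4-dichlorophenyl urea but also a different group on the other ring, so its value only hints that this aryl swap is not large. Compound 4 is therefore expected to stay near compound 1, the estimated step being a number 7 percentage points higher from compound 1 to compound 4 (within the scatter). The estimate for compound 4 is 92%, between 78% and 106%.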

Compound 4, a percentage reported as activity, at one concentration (the size of the read-out at that concentration, not a potency): 91%
Beside the measured number, compound 4's estimate is 1 percentage points above it; low and high end bracket the measured number.
By their numbers in this assay, from the lowest: compounds 1, 4, 3 and 2 (each within the scatter of the next, the first and the last beyond it).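

In this assay, the direct swap of 3-(trifluoromethyl)phenyl for 3,4-dichlorophenyl on the amide-type nitrogen gives no readable change (a number 6 percentage points higher from compound 1 to compound 4 (within the scatter)). Methyl in place of hydrogen on the oxygen on the aromatic ring also stays within the scatter (a number 6 percentage points lower from compound 3 to compound 4 (within the scatter)), as does the step that restores a urea nitrogen and carries the dichlorophenyl group (a number 10 percentage points lower from compound 2 to compound 4 (within the scatter)). No available evidence explains these results.

As far as these compounds go, whether a smaller or non-aromatic group on that nitrogen, such as methyl or cyclohexyl, would shift the number stays open.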